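Furan-2-yl for 4-methoxyphenyl at the enone end

The compounds below may be only part of what the source reports. "The series", "measured", "known", "first", "only" and "open" are said of these compounds alone.

Measured in a functional assay on the whole organism (strain albino) for inhibition, with Rattus norvegicus as the target, read by paw edema, with stated times of 30 min and 4 h, at a dose of 100 mg/kg by the oral route; a higher number here means more inhibition at the dose given (going by the name of the read-out), a lower number less inhibition:
compound 1 `O=C(CBr)Nc1ccc(C(=O)/C=C/c2ccco2)cc1` gives 33%
compound 2 `O=C(CO[N+](=O)[O-])Nc1ccc(C(=O)/C=C/c2ccco2)cc1` gives 40%
compound 3 `COc1ccc(/C=C/C(=O)c2ccc(NC(=O)C(C)Br)cc2)cc1` gives 38%

Compound 3 stands second highest of the three numbers in this assay; its nearest neighbour is compound 2 and its furthest is compound 1. Both gaps are within the scatter, so the three measured compounds cannot be told apart.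

Among the measured compounds shown here, the only single-point step measured is a number 7 percentage points higher from compound 1 to compound 2 (within the scatter), a change on the amide side chain and within the scatter.

Compound 4 `CC(Br)C(=O)Nc1ccc(C(=O)/C=C/c2ccco2)cc1` is not yet measured. It differs from compound 3 as follows: furan-2-yl in place of 4-methoxyphenyl on a double-bonded chain carbon bound to a double-bonded chain carbon

For the measured compounds named here, no measured step touches this position. The change brings compound 4 onto the same furan-bearing side as compound 1 and compound 2, while keeping the 2-bromopropanamide side of compound 3; the values of compound 1 and compound 2 in this assay sit in the same band as that of compound 3. There is therefore no ground to expect a step beyond the scatter in either direction.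

Compound 4 is expected to give about 36% in this assay, with a range of 25% to 48%. The estimated step from compound 3 to compound 4 is a number 2 percentage points lower from compound 3 to compound 4 (within the scatter), expected to lie within the scatter.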

Compound 4, a percentage reported as inhibition, in the whole organism at one dose (the size of the read-out at that dose, not a potency): 36%
The estimate for compound 4 equals the measured number at the digits printed; low and high end bracket the measured number.
By their numbers in this assay, from the lowest: compounds 1, 4, 3 and 2 (each within the scatter of the next).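

In this assay the enone end now has a step of its own: a number 2 percentage points lower from compound 3 to compound 4 (within the scatter), so furan-2-yl and 4-methoxyphenyl on a double-bonded chain carbon bound to a double-bonded chain carbon cannot be told apart with the 1-bromoethyl side chain in place. On the furan-bearing side, the side chain gains two further readings, a number 4 percentage points lower from compound 2 to compound 4 (within the scatter) for 1-bromoethyl in place of (nitrooxy)methyl and a number 3 percentage points higher from compound 1 to compound 4 (within the scatter) for methyl in place of hydrogen on a saturated chain carbon bound to a bromine atom and a carbonyl carbon, and neither step separates the compounds. No measurement on hand bears on why these changes leave the number within the scatter.

Still open, from the compounds shown here alone, is whether an amine or a carboxylic acid carried by the aromatic ring at this place would give a number outside the shared band. Going by these compounds, these readings also come from a single dose, so they say nothing about potency, and whether furan-2-yl and 4-methoxyphenyl also stay level with a (nitrooxy)methyl side chain remains unknown.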